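This account rests on a few compounds, and the source may have more. Where it says the series, first, only, none or still open, it means among the compounds named here.

Measured so far in an assay on V79 cells for inhibition of cytochrome P450 11B2, mitochondrial (Homo sapiens), read by HTRF, with a stated time of 1 h; a higher number here means a weaker inhibitor, a lower number a stronger inhibitor:
compound 1, `c1cncc(-c2nc3ccccc3n2C2CC2)c1`: 49 nM
compound 2, `N#Cc1cc2c(cc1F)nc(-c1cncc(F)c1)n2C1CC1`: 1 nM
compound 3, `CC(C)(C)n1c(-c2cccnc2)nc2ccc(F)cc21`: > 5000 nM

Compound 3 stands at the edge of what this assay reports: its value of > 5000 nM is a limit of the assay, not a number, and it is the one entry that sits there (the limit of > 5000 nM in this assay, at which 1 of the 3 values shown sits). Compound 1 and compound 2 both give numbers; compound 2 gives the lower of the two. No pair among these three differs in only one place, so no single measured step is available, and the shared core is the only thread between them.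

Compound 4, `Fc1ccc2nc(-c3cccnc3)n(C3CCC3)c2c1`, differs from compound 3 in one place: cyclobutyl in place of tert-butyl on an aromatic nitrogen. Nothing measured covers this change directly. The small ring on the aromatic nitrogen is closer in kind to the cyclopropyl of compound 1, which gives 49 nM, though compound 1 and compound 4 also differ elsewhere. The step from compound 3 to compound 4 is therefore expected to run downward, away from the limit, and is estimated at an at least 20-fold lower number from compound 3 to compound 4 (1.30 log units; beyond the scatter), its size uncertain since compound 3 is only a limit. Compound 4 is expected to give about 250 nM, in a range from 30 nM to 2500 nM.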

Compound 4, half-maximal inhibitory concentration: > 5000 nM
Compound 4 was reported as a limit (the forecaster's own chance of this, stated with the estimate: 15%); at least 20-fold (1.30 log units) between middle value and limit.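

Compound 3 and compound 4 both stand as limits of the assay and not as numbers, so no step between them can be read in this assay: the limit of > 5000 nM in this assay, at which 2 of the 4 values shown sit.

The compounds shown leave open whether cyclobutyl and tert-butyl on the aromatic nitrogen differ at all in this assay.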